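Removing the Methoxycarbonyl Group from Compound 1

The source may hold more compounds than are shown below. What is called first, only, known or untested is meant among the compounds shown, and "the series" means these compounds.

Compound 1 `COC(=O)c1ccnc(O[C@@H]2CC[C@@H](C)N(C(=O)c3ccccc3-n3nccn3)C2)c1` was tested in an assay on CHO-K1 cells for displacement of a labelled ligand from Orexin receptor type 2 (Homo sapiens), read by radioligand binding (on this read-out higher numbers stand for weaker inhibition and lower numbers for stronger inhibition), where compound 1 gives 3.9 nM. Two close relatives share its core. Compound 2 `Cc1cccc(O[C@@H]2CC[C@@H](C)N(C(=O)c3ccccc3-n3nccn3)C2)n1` carries a 6-methylpyridin-2-yl on the oxygen on a saturated carbon, and in this assay compound 2 gives 7.6 nM. Compound 3 `C[C@@H]1CC[C@@H](Oc2cc(-c3ccccc3)ccn2)CN1C(=O)c1ccccc1-n1nccn1` has a phenyl where compound 1 has the methoxycarbonyl, and in this assay compound 3 gives 3.8 nM. Among these three numbers compound 1 sits second highest, but the step of a 1.9-fold higher number from compound 1 to compound 2 (0.29 log units; within the scatter) and the step of a 1.0-fold lower number from compound 1 to compound 3 (0.01 log units; within the scatter) both fall within the ordinary scatter, so none of the three compounds can be told apart on this read-out.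

Compound 4 `C[C@@H]1CC[C@@H](Oc2ccccn2)CN1C(=O)c1ccccc1-n1nccn1` is the next member: hydrogen in place of methoxycarbonyl on an aromatic carbon. Both measured steps speak to this change. Replacing the methoxycarbonyl with a phenyl stayed within the scatter, and exchanging the whole substituted pyridine for a methylpyridine also stayed within the scatter. Deleting the group altogether is therefore expected to produce no shift beyond the scatter in this assay, with at most a slight drift toward a higher number. The expected step is a 1.5-fold higher number from compound 1 to compound 4 (0.19 log units; within the scatter). Compound 4 is estimated to give 6 nM, between 2.5 nM and 15 nM.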

Compound 4, inhibition constant: 2400 nM
Compound 4: the middle estimate sits 400-fold (2.60 log units) below what was measured; the whole stated range lies below it.
By their numbers in this assay, from the lowest: compounds 3, 1 and 2 (each within the scatter of the next); then compound 4.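

In this assay, the unsubstituted pyridin-2-yl of compound 4 stands far from all three substituted relatives: the change from methoxycarbonyl to hydrogen gives a 620-fold higher number from compound 1 to compound 4 (2.79 log units; beyond the scatter) and the change from phenyl to hydrogen gives a 630-fold higher number from compound 3 to compound 4 (2.80 log units; beyond the scatter) on the same aromatic carbon, opposite the ring nitrogen. The earlier compounds shown here showed only that one substituent could replace another on the pyridine with no step beyond the scatter, which said nothing about leaving the ring with no substituent at all. Here the ring turns out to tolerate very different groups yet not their absence, and even a single methyl counts, with a 320-fold higher number from compound 2 to compound 4 (2.50 log units; beyond the scatter) as the step for hydrogen in place of methyl.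

As far as these compounds go, whether a fluorine atom, a hydroxyl or an amine on the carbon that held the methoxycarbonyl would bring back the strong inhibition of compound 1 remains open, as does how small a group can be and still do so. What lies behind so steep a loss also stays open, as nothing shown here bears on it.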